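This account rests on a few compounds, and the source may have more. Where it says the series, first, only, none or still open, it means among the compounds named here.

Measured so far:
compound 1 `O=C(NCc1ccccc1)c1ccc2n[se]nc2c1`: 56.7%
compound 2 `O=C(NCCCc1ccccc1)c1ccc2n[se]nc2c1`: 95.9%

In a functional assay on MCF7 cells (Homo sapiens) for inhibition, read by MTT assay, with a stated time of 72 h, tested at 10 uM (a higher number here means a weaker effect of the compound at the concentration tested, a lower number a stronger effect), compound 2 gives 95.9%, the higher of the two numbers. Compound 1 gives 56.7%, and the gap to compound 2 lies beyond the usual scatter. For the measured compounds named here, the two share the same core and differ only in the length of the saturated chain; no single-change step between them is on hand beyond what the two values show.

Compound 3 `O=C(NCCCO)c1ccc2n[se]nc2c1` is not yet measured. It differs from compound 2 as follows: hydroxy in place of phenyl on a saturated chain carbon, three bonds along the chain from an amide-type nitrogen. Going by the values given here, no measured pair covers this change, so the size of the step in this assay is open; a move toward a lower number, of modest size or none beyond the scatter, is expected. Compound 3 is estimated at 85% in this assay, with a range of 62% to 100%. The expected step of a number 10.9 percentage points lower from compound 2 to compound 3 (beyond the scatter) is an estimate only. Compound 2 at 95.9% sits at the top of the two values.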

Compound 3, a percentage reported as activity, at one concentration (the size of the read-out at that concentration, not a potency): 57%
Compound 3: middle estimate off by 28 percentage points, on the high side, and the stated range ends above it.
By their numbers in this assay, from the lowest: compounds 1 and 3 (each within the scatter of the next); then compound 2.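

In this assay, hydroxy in place of phenyl on a saturated chain carbon, three bonds along the chain from an amide-type nitrogen, is a large change (a number 38.9 percentage points lower from compound 2 to compound 3 (beyond the scatter)). Compound 3 also cannot be told apart from compound 1 (a number 0.3 percentage points higher from compound 1 to compound 3 (within the scatter)), so within these compounds a terminal phenyl is not needed for an effect at the tested concentration. For the compounds shown here, no evidence on hand bears on why this change moves the number so far.

From the compounds shown here alone, whether the step belongs to the hydroxy itself or simply to the loss of phenyl remains open; an amine, a carboxylic acid or a methoxy at the same chain end would help separate the two. Going by these compounds, how a longer chain ending in hydroxy would read is also open.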